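The compounds below may be only part of what the source reports. "The series", "measured", "known", "first", "only" and "open" are said of these compounds alone.

Compound 3 `C/C=C/C=C/C(=O)N[C@H](C(=O)NCCCCCCCCCCCCCC)[C@@H](C)O` gives in a functional assay on HepG2 cells (Homo sapiens) for cytotoxicity, read by MTT assay, with a stated time of 48 h (on this read-out higher numbers stand for weaker inhibition and lower numbers for stronger inhibition), only a limit, > 400000 nM, and it is the compound that sits at the limit of > 400000 nM in this assay, at which 1 of the 3 values shown sits. Among the compounds with values here, compound 2 `CCCCCCCCCCCCCCNC(=O)[C@@H](NC(=O)c1cccs1)[C@@H](C)O` gives 88400 nM in this assay, and the measured change an at least 4.5-fold higher number from compound 2 to compound 3 (0.65 log units; beyond the scatter) is the one step that bears directly on the shared core. Compound 1 `CCCCCCCCCCCCNC(=O)[C@@H](NS(=O)(=O)c1cccs1)[C@@H](C)O` differs from compound 2 in two places, and in this assay compound 1 gives 25900 nM. Compound 4 `CCCCCCCCCCCCCCNC(=O)[C@@H](NS(=O)(=O)c1cccs1)[C@@H](C)O` carries (thiophen-2-yl)sulfonyl in place of (penta-1,3-dien-1-yl)carbonyl on an amine nitrogen. Reversing the step seen from compound 2 to compound 3 should bring the number back down, and compound 1 at 25900 nM against compound 2 at 88400 nM hints that the sulfonyl may lower it further. Compound 4 is therefore expected to give about 40000 nM, between 12000 nM and 150000 nM. For compound 4 this means an expected step of an at least 10-fold lower number from compound 3 to compound 4 (1.00 log units; beyond the scatter).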

Compound 4, half-maximal inhibitory concentration: 21600 nM
Estimate against measurement, compound 4: 1.9-fold (0.27 log units) above; the measured number falls inside the stated range.
By their numbers in this assay, from the lowest: compounds 4 and 1 (each within the scatter of the next); then compound 2. At a limit, above all of these: compound 3.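

With the thiophen-2-yl kept, (thiophen-2-yl)sulfonyl in place of (thiophen-2-yl)carbonyl on the amine nitrogen gives a 4.1-fold lower number from compound 2 to compound 4 (0.61 log units; beyond the scatter), so the link itself counts in this assay, while the longer chain of the sulfonyl pair gives a 1.2-fold lower number from compound 1 to compound 4 (0.08 log units; within the scatter). Exchanging the whole (penta-1,3-dien-1-yl)carbonyl group gives an at least 18-fold lower number from compound 3 to compound 4 (1.26 log units; beyond the scatter), and this size is only a bound. Compound 3 gives no number, only a limit: the limit of > 400000 nM in this assay, at which 1 of the 4 values shown sits.

From the compounds shown here alone, whether a phenyl ring in place of the thiophen-2-yl on the sulfonyl keeps this number stays open. So does the effect of a much shorter chain, such as octyl.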